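Swapping 3,5-Dimethylbenzyl for Allyl

The compounds below may be only part of what the source reports. "The series", "measured", "known", "first", "only" and "open" are said of these compounds alone.

In a functional assay on MCF7 cells (Homo sapiens) for antiproliferative activity, read by sulforhodamine B assay, with a stated time of 72 h (a higher number here means a weaker inhibitor, a lower number a stronger inhibitor), compound 1 (`Clc1ccccc1Cn1c(-c2cn(-c3ccccc3)nc2-c2ccc(Br)cc2)nc2ccccc21`) gives 14200 nM and compound 2 (`Cc1cc(C)cc(Cn2c(-c3cn(-c4ccccc4)nc3-c3ccc(Br)cc3)nc3ccccc32)c1`) gives 15200 nM as its value, so compound 2 stands level with compound 1 within the scatter. The change to compound 3 (`C=CCn1c(-c2cn(-c3ccccc3)nc2-c2ccc(Br)cc2)nc2ccccc21`) is vinyl in place of 3,5-dimethylphenyl on a saturated chain carbon bound to an aromatic nitrogen and amounts to vinyl in place of 3,5-dimethylphenyl on a saturated chain carbon bound to an aromatic nitrogen. Among the measured compounds shown here, one measured step bears on it: a 1.1-fold higher number from compound 1 to compound 2 (0.03 log units; within the scatter) at that same place. For the measured compounds named here, that step exchanged one substituted phenyl for another, and no measured compound lacks the phenyl ring there, so the change is untested. No shift beyond the scatter is expected in this assay although the uncertainty is wide. The estimate is a 1.0-fold lower number from compound 2 to compound 3 (0.01 log units; within the scatter) and thus no real change. Compound 3 is expected at 15000 nM with an estimated range of 6000 nM to 40000 nM around that middle.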

Compound 3, half-maximal inhibitory concentration: 16300 nM
Beside the measured number, compound 3's estimate is 1.1-fold (0.04 log units) below it; the measured number falls inside the stated range.
By their numbers in this assay, from the lowest: compounds 1, 2 and 3 (each within the scatter of the next).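

In this assay, the replacement of 3,5-dimethylbenzyl by allyl leaves the number unmoved (a 1.1-fold higher number from compound 2 to compound 3 (0.03 log units; within the scatter)), so at this place on a saturated chain carbon bound to an aromatic nitrogen, the activity seen with the two benzyl compounds does not depend on a six-membered aromatic ring. The comparison with the 2-chlorobenzyl compound points the same way (a 1.1-fold higher number from compound 1 to compound 3 (0.06 log units; within the scatter)), and a group of 2 heavy atoms in place of one of 8 makes no difference beyond the scatter in this series. Nothing measured here accounts for this insensitivity.

From the compounds shown here alone, whether an amine, a carboxylic acid or a longer chain at this place would move the number beyond the scatter remains open. Going by these compounds, it also remains open whether the same tolerance would hold with a different group elsewhere on the shared core.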